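Swapping Methoxy for Methyl in Compound 3

The source may hold more compounds than are shown below. What is called first, only, known or untested is meant among the compounds shown, and "the series" means these compounds.

In a functional assay on A549 cells (Homo sapiens) for antiproliferative activity, read by MTT assay, with a stated time of 48 h (a higher number here means a weaker inhibitor, a lower number a stronger inhibitor), compound 3 `COc1ccc(-c2nnc(NC(=O)/C=C/c3ccc(C)cc3)s2)cc1` gives 0.58 ug/mL and compound 2 `COc1ccc(/C=C/C(=O)Nc2nnc(-c3ccc(C)cc3)s2)cc1` gives 0.66 ug/mL, two values within the usual scatter of each other. Compound 1 `Cc1ccc(/C=C/C(=O)Nc2nnc(-c3ccc(Cl)cc3)s2)cc1` stands apart at 1.25 ug/mL. That gap is a 2.2-fold lower number from compound 1 to compound 3 (0.33 log units; beyond the scatter), and it comes with methoxy in place of chloro on an aromatic carbon.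

Compound 4 `Cc1ccc(/C=C/C(=O)Nc2nnc(-c3ccc(C)cc3)s2)cc1` changes that same place again, with methyl in place of methoxy, turning 4-methoxyphenyl into 4-methylphenyl (methyl in place of methoxy on an aromatic carbon). Within the data shown here, the only measured step at this place is the modest one just described, and no measured compound shows methyl there with everything else held constant. The closest hint is compound 2, which carries the 4-methylphenyl group and still gives 0.66 ug/mL, though it also differs elsewhere. A small rise in this assay is therefore expected, one that stays within the scatter. The expected change is a 1.4-fold higher number from compound 3 to compound 4 (0.14 log units; within the scatter). For compound 4 the estimate is 0.8 ug/mL, with an expected range from 0.4 ug/mL to 1.6 ug/mL.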

Compound 4, half-maximal inhibitory concentration: 1.08 ug/mL
For compound 4 the middle estimate is 1.4-fold (0.13 log units) below the measured one, within the range that was stated.
By their numbers in this assay, from the lowest: compounds 3, 2, 4 and 1 (each within the scatter of the next, the first and the last beyond it).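

Methyl and methoxy at this position cannot be told apart in this assay (a 1.9-fold higher number from compound 3 to compound 4 (0.27 log units; within the scatter)), and neither can methyl and chloro (a 1.2-fold lower number from compound 1 to compound 4 (0.06 log units; within the scatter)), even though the methoxy and chloro compounds do separate from each other. So methyl falls within the scatter of both neighbours, and the small gap between chloro and methoxy remains the only step at this position that exceeds the scatter. The same swap on the other aromatic ring also stays within the scatter (a 1.6-fold higher number from compound 2 to compound 4 (0.21 log units; within the scatter)), and nothing measured here gives a reason for any of these numbers.

All three groups at this position are small and uncharged, so the compounds shown leave open how an amine or a carboxylic acid would behave there. They also leave open what a longer chain, such as ethoxy, would do at the same place.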